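The source may hold more compounds than are shown below. What is called first, only, known or untested is meant among the compounds shown, and "the series" means these compounds.

The measured compounds:

compound 1, `COc1ccc(/C=C/S(=O)(=O)Cc2ccc(OC)cc2)cc1`: > 20000 nM
compound 2, `COc1ccc(CS(=O)(=O)/C=C/c2ccc(F)cc2)cc1`: 2000 nM
compound 3, `COc1ccc(CS(=O)(=O)/C=C/c2ccc(F)cc2OC)cc1`: 15000 nM

All three were tested in a functional assay on DLD-1 cells (Homo sapiens) for antiproliferative activity, read by trypan blue exclusion; on this read-out lower numbers stand for stronger inhibition and higher numbers for weaker inhibition. For compound 1 the value > 20000 nM is a limit of the assay, not a number: compound 1 stands at the limit of > 20000 nM in this assay, at which 1 of the 3 values shown sits. In this assay compound 2 gives 2000 nM and compound 3 gives 15000 nM.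

Compound 2 and compound 3 differ by methoxy in place of hydrogen on an aromatic carbon. That change gives a 7.5-fold higher number from compound 2 to compound 3 (0.88 log units; beyond the scatter).

Compound 4, `COc1ccc(CS(=O)(=O)/C=C/c2ccc(OC)c(OC)c2)cc1`, has not yet been measured. It differs from compound 1 by methoxy in place of hydrogen on an aromatic carbon, the same kind of change as from compound 2 to compound 3, but not the same: in compound 4 the new group sits ortho to a methoxy group and meta to a large group, whereas in compound 3 it sits ortho to a large group and meta to a fluoro group. The cores of compound 1 and compound 2 themselves differ by methoxy in place of fluoro on an aromatic carbon, a change that gives an at least 10-fold lower number from compound 1 to compound 2 (1.00 log units; beyond the scatter).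

Compound 4 is expected to show a step that the limit leaves unreadable from compound 1 to compound 4, with an estimated value of 30000 nM, most likely reported again only as a limit. This expectation rests on a 7.5-fold higher number from compound 2 to compound 3 (0.88 log units; beyond the scatter) and on compound 1 already standing at the limit of > 20000 nM in this assay, at which 1 of the 3 values shown sits.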

Compound 4, half-maximal inhibitory concentration: > 20000 nM
Compound 4 gave a limit, no number; the forecaster's own chance of this, stated with the estimate: 75%; the middle value lies beyond the limit too.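

In this assay compound 4 gives > 20000 nM, which is a limit of the assay and not a number. Within the data shown here, compound 1 and compound 4 both stand at a limit, so no step between them can be read: the limit of > 20000 nM in this assay, at which 2 of the 4 values shown sit. The compounds shown leave open whether methoxy in place of hydrogen on an aromatic carbon changes the activity of the core of compound 1 at all.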